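Fluoro in place of methoxy: what to expect for compound 3

A few compounds are considered here, and "the series" means these few. Any claim that something is new, unique, unknown or untested is made for them only; others in the source may bear on it.

Compound 2 `COc1ccc2c(c1)n(C(=O)NCCN1CCN(C)CC1)c(=O)n2C(C)C` carries a methoxy group on its aromatic ring, and compound 1 `CC(C)n1c(=O)n(C(=O)NCCN2CCN(C)CC2)c2cc(Cl)ccc21` differs from it only by a chloro in place of that methoxy. In a functional assay for antagonist activity at 5-hydroxytryptamine receptor 4 (Cavia porcellus) (on this read-out higher numbers stand for higher potency (the scale is a negative logarithm) and lower numbers for lower potency), compound 2 reaches only a limit of the assay, < 6. In this assay compound 1 likewise reaches only a limit, < 6. The step that the two limits leave unreadable from compound 1 to compound 2 therefore cannot be read, since both compounds stand at the limit of < 6 in this assay, at which 2 of the 2 values shown sit. Compound 2 thus stands at the floor of what the assay reports, with no numerical potency attached to it.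

Compound 3 `CC(C)n1c(=O)n(C(=O)NCCN2CCN(C)CC2)c2cc(F)ccc21` differs from compound 2 by fluoro in place of methoxy on an aromatic carbon. Going by the values given here, no measured step gives a readable size for a change of this kind, because the single step measured, a step that the two limits leave unreadable from compound 1 to compound 2, is hidden by the two limits. With both neighbours at the limit, compound 3 is expected to stay close to that floor as well. Compound 3 is estimated at 5.5 in this assay, within a range from 4.5 to 6.3. This expectation amounts to a step that the limit leaves unreadable from compound 2 to compound 3, which is expected to lie within the scatter.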

Compound 3, negative logarithm of the antagonist equilibrium constant: 6.88
The estimate for compound 3 lay 1.38 log units below the measured number; measured number above the stated range.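

The position on the aromatic carbon, meta to a fused ring and para to a fused ring, had yielded no readable step, but it now proves able to move the read-out. In this assay, placing fluoro there in place of methoxy gives a number at least 0.88 log units higher from compound 2 to compound 3 (beyond the scatter), and placing it there in place of chloro gives a number at least 0.88 log units higher from compound 1 to compound 3 (beyond the scatter), which makes compound 3 the most potent of the three compounds shown and the only one of them with a numerical potency. The exchange of chloro for methoxy still cannot be read, so these two groups remain unordered at this position, and the gain with fluoro is seen only against compounds at the assay's limit: the limit of < 6 in this assay, at which 2 of the 3 values shown sit.

As far as these compounds go, the full size of both steps stays open, as each has only a lower bound, and a single fluoro compound cannot show whether the gain is particular to fluoro or extends to other groups. From the compounds shown here alone, whether a bare hydrogen, a nitrile or a trifluoromethyl group on the same carbon would match fluoro remains unknown, as does whether fluoro would give a similar step on another carbon of the ring.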